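Fluoro on the aryl ring of the hydroxyethyl amide

A few compounds are considered here, and "the series" means these few. Any claim that something is new, unique, unknown or untested is made for them only; others in the source may bear on it.

Measured so far:
compound 1 `O=C(Nc1ccccc1)c1c(NO)cc(-c2ccc(F)cc2)oc1=O`: 10300 nM
compound 2 `O=C(NCCO)c1c(NO)cc(-c2ccccc2)oc1=O`: > 20000 nM

In an ADME assay on Huh-7 cells (Homo sapiens) for cytotoxicity, read by a luciferase reporter and WST assay, with a stated time of 3 days (a higher number here means that more compound is tolerated, a lower number that less compound is tolerated), compound 1 gives 10300 nM. For compound 2 the assay reports only a limit, > 20000 nM, and that is a bound rather than a number. Compound 2 therefore sits at the limit of > 20000 nM in this assay, at which 1 of the 2 values shown sits. Compound 3 `O=C(NCCO)c1c(NO)cc(-c2ccc(F)cc2)oc1=O` is not yet measured. It differs from compound 2 by fluoro in place of hydrogen on an aromatic carbon, para to a large group. Among the compounds with values here, no measured pair isolates this change, so no step size is on record; compound 1 also carries the 4-fluorophenyl but differs elsewhere as well, and only its own value is known. The expectation is no shift beyond the scatter, an estimated step of a number no higher from compound 2 to compound 3 (the limit leaves the size open). Compound 3 is expected near 20000 nM, within 8000 nM to 50000 nM, with a fair chance that this assay again returns only a limit.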

Compound 3, half-maximal cytotoxic concentration: > 20000 nM
Compound 3 was reported as a limit; the forecaster's own chance of this, stated with the estimate: 55%; the middle value lies on the limit itself.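

Within the data shown here, compound 1 and compound 3 now form the first pair that differs in one place, 2-hydroxyethyl in place of phenyl on the amide-type nitrogen with the 4-fluorophenyl kept: in this assay the step reads an at least 1.9-fold higher number from compound 1 to compound 3 (0.28 log units; that floor lies within the scatter). As far as these compounds go, that step is only a floor, so the pair gives no firm separation and its true size stays open. The step from phenyl to 4-fluorophenyl on the hydroxyethyl amide cannot be read, and both compounds give the same reading: the limit of > 20000 nM in this assay, at which 2 of the 3 values shown sit.

Still open, from the compounds shown here alone, is whether fluoro on the aryl ring shifts tolerance at all on the hydroxyethyl amide, with neither compound giving a number. Also open, going by these compounds, is how an amide carrying a longer chain, an amine or a carboxylic acid in place of 2-hydroxyethyl would read in this assay.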